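The compounds below may be only part of what the source reports. "The series", "measured", "known", "first", "only" and "open" are said of these compounds alone.

Compound 2 `CC(C)(C)c1ccc(C(=O)NC(=S)N2CCc3c(OCCCCCOc4ccc(Cl)cc4)cccc32)cc1` is examined in an ADME assay on Huh-7 cells (Homo sapiens) for cytotoxicity; a higher number here means that more compound is tolerated, a lower number that less compound is tolerated. Compound 2 gives > 50000 nM, which is a limit of the assay and not a number (the limit of > 50000 nM in this assay, at which 1 of the 2 values shown sits). Compound 1 `O=C(NC(=S)N1CCc2c(OCCCCCOc3ccc(Cl)cc3)cccc21)c1cccc([N+](=O)[O-])c1` gives 12100 nM in this assay. Among the measured compounds shown here, the only measured step is an at least 4.1-fold higher number from compound 1 to compound 2 (0.61 log units; beyond the scatter), a change of the group on the carbonyl carbon. Compound 3 `O=C(NC(=S)N1CCc2c(OCCCCCOc3ccc(Cl)cc3)cccc21)c1ccoc1` carries the change (furan-3-yl in place of 4-(tert-butyl)phenyl on a carbonyl carbon), again at that carbonyl carbon. Because compound 2 sits at the limit > 50000 nM, a move back to a measurable number seems more likely than a higher one, so compound 3 is expected to show an at least 1.6-fold lower number from compound 2 to compound 3 (0.22 log units; that floor lies within the scatter). The estimate for compound 3 is 30000 nM, within 10000 nM to 60000 nM.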

Compound 3, half-maximal cytotoxic concentration: 20100 nM
Estimate against measurement, compound 3: 1.5-fold (0.17 log units) above, within the range that was stated.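

Furan-3-yl in place of 4-(tert-butyl)phenyl on the carbonyl carbon gives an at least 2.4-fold lower number from compound 2 to compound 3 (0.39 log units; beyond the scatter), so not every group at this place matches compound 2. The value of compound 2 is a limit of the assay and not a number, so this step gives only a floor: the limit of > 50000 nM in this assay, at which 1 of the 3 values shown sits. Furan-3-yl in place of 3-nitrophenyl gives a 1.7-fold higher number from compound 1 to compound 3 (0.22 log units; within the scatter), so this assay does not separate these two groups.

On these data alone, whether a plain phenyl group or a cyclohexyl group on the carbonyl carbon would behave like compound 2, or like compound 1 and compound 3, stays open.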